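This account rests on a few compounds, and the source may have more. Where it says the series, first, only, none or still open, it means among the compounds named here.

Compound 2 `COC(=O)/C=C/c1cccc(N(Cc2ccc(/C=C/c3ccc(F)cc3)cc2)C(=O)C2CCCCC2)c1` has been tested in an assay on isolated protein with Bile acid receptor (Homo sapiens) as the target (on this read-out higher numbers stand for an effect only at larger amounts of compound and lower numbers for an effect already at smaller amounts), where compound 2 gives 185 nM. Among the two compounds measured so far this is the higher of the two numbers. Going by the values given here, the only neighbour is compound 1 `COC(=O)/C=C/c1cccc(N(Cc2ccc(/C=C/c3cccc(F)c3)cc2)C(=O)C2CCCCC2)c1`, which in this assay gives 86 nM; the step from compound 1 to compound 2 is a 2.2-fold higher number from compound 1 to compound 2 (0.33 log units; beyond the scatter), which comes from moving a single fluorine atom within the same ring.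

Compound 3 `COC(=O)/C=C/c1cccc(N(Cc2ccc(-c3cc(Cl)ccc3OC)cc2)C(=O)C2CCCCC2)c1` differs from compound 2 in one place: 5-chloro-2-methoxyphenyl in place of 2-(4-fluorophenyl)ethenyl on an aromatic carbon. This replaces a ring that hangs on a double bond with a ring joined directly, and swaps a fluorine for a chlorine and a methoxy group.

Among the compounds with values here, the one measured step shows that even a small change in this part of the molecule is visible in this assay, but it does not cover a change of this kind, so the direction remains uncertain. On balance compound 3 is expected to give a higher number, the estimated step from compound 2 to compound 3 being a 2.2-fold higher number from compound 2 to compound 3 (0.33 log units; beyond the scatter). The estimate for compound 3 is therefore 400 nM, with a range from 100 nM to 2000 nM.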

Compound 3, half-maximal effective concentration: 233 nM
For compound 3 the middle estimate is 1.7-fold (0.23 log units) above the measured one; measured number inside the range.
By their numbers in this assay, from the lowest: compound 1; then compounds 2 and 3 (each within the scatter of the next).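

In this assay, putting 5-chloro-2-methoxyphenyl in place of 2-(4-fluorophenyl)ethenyl gives a 1.3-fold higher number from compound 2 to compound 3 (0.10 log units; within the scatter) and so leaves compound 2 and compound 3 indistinguishable, even though the double bond outside the ring is gone, the ring is joined directly to the aromatic carbon, and a hydrogen-bond acceptor has come in. This position therefore accepts two quite different groups of the same heavy-atom count with no readable difference, while the same exchange made on the 2-(3-fluorophenyl)ethenyl group gives a 2.7-fold higher number from compound 1 to compound 3 (0.43 log units; beyond the scatter) as a modest step beyond the scatter. The outcome of the exchange thus depends on which fluorinated group it starts from, and no supporting data are available to explain these numbers.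

From the compounds shown here alone, the chlorine, the methoxy group and the loss of the double bond all change together here, so their separate contributions remain unknown. Going by these compounds, it also remains open how this position would respond to a plain phenyl ring or to a ring carrying an amine or a carboxylic acid.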